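This account rests on a few compounds, and the source may have more. Where it says the series, first, only, none or still open, it means among the compounds named here.

Measured in an assay on HEK293 cells for displacement of a labelled ligand from growth hormone secretagogue receptor type 1 (Homo sapiens), with a stated time of 60 min (a higher number here means a weaker inhibitor, a lower number a stronger inhibitor), so far:
compound 1, `CN1CCN(CCCS(=O)(=O)c2ccc3nc(NC(=O)NC(=O)c4cc(C5CC5)ccc4Cl)sc3c2)CC1`: 0.33 nM
compound 2, `CN1CCN(CCCS(=O)(=O)c2ccc3nc(NC(=O)NC(=O)c4cc(-n5cccc5)ccc4Cl)sc3c2)CC1`: 0.15 nM
compound 3, `CCOc1ccc(Cl)c(C(=O)NC(=O)Nc2nc3ccc(S(=O)(=O)CCCN4CCN(C)CC4)cc3s2)c1`: 0.31 nM

Compound 3 holds the second highest of the three numbers. Its nearest neighbour is compound 1, with a 1.1-fold lower number from compound 1 to compound 3 (0.03 log units; within the scatter); the furthest is compound 2, with a 2.1-fold higher number from compound 2 to compound 3 (0.32 log units; beyond the scatter). Among the compounds with values here, the only step beyond the scatter among the measured pairs is a 2.2-fold lower number from compound 1 to compound 2 (0.34 log units; beyond the scatter), and even that is modest.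

Compound 4, `CN1CCN(CCCS(=O)(=O)c2ccc3nc(NC(=O)NC(=O)c4cc5c(ccn5C)cc4Cl)sc3c2)CC1`, is the next to be run in this assay. Its change from compound 3: 5-chloro-1-methyl-1H-indol-6-yl in place of 2-chloro-5-ethoxyphenyl on a carbonyl carbon.

Within the data shown here, no measured step bears directly on this change. The three measured steps each swap one group on the aromatic ring (cyclopropyl, 1H-pyrrol-1-yl, ethoxy) and leave the rest untouched, whereas here the whole 2-chloro-5-ethoxyphenyl is exchanged for 5-chloro-1-methyl-1H-indol-6-yl. What the series does show is that variation in this part of the molecule has so far moved the number only modestly, so the step expected for compound 4 is small, with no clear direction: a 1.0-fold lower number from compound 3 to compound 4 (0.01 log units; within the scatter). The estimate for compound 4 in this assay is 0.3 nM, within a range of 0.1 nM to 1 nM, widened for the untested ring fusion.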

Compound 4, half-maximal inhibitory concentration: 0.57 nM
Beside the measured number, compound 4's estimate is 1.9-fold (0.28 log units) below it; the range from low to high includes it.
By their numbers in this assay, from the lowest: compound 2; then compounds 3, 1 and 4 (each within the scatter of the next).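

In this assay, within the data shown here, the change is the first to exchange the whole aryl group on the carbonyl carbon, and a second fused aromatic ring in 5-chloro-1-methyl-1H-indol-6-yl leaves the number within the scatter of two earlier compounds, with a 1.8-fold higher number from compound 3 to compound 4 (0.26 log units; within the scatter) and with a 1.7-fold higher number from compound 1 to compound 4 (0.24 log units; within the scatter) as the two readings. Among these compounds, compound 2 alone separates from it, with a 3.8-fold higher number from compound 2 to compound 4 (0.58 log units; beyond the scatter) as the largest step so far, though still modest, so the 1H-pyrrol-1-yl group is the only earlier substituent distinguishable from the fused ring. No measurement given here explains this difference.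

On these data alone, with a single fused example, the contribution of the methyl on the ring nitrogen remains open. Also open, as far as these compounds go, is how the number responds to a polar replacement such as an amine or a carboxylic acid at the aromatic carbon that carries ethoxy in compound 3.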